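Second chloro on the core: from compound 1 to compound 4

The source may hold more compounds than are shown below. What is called first, only, known or untested is meant among the compounds shown, and "the series" means these compounds.

Measured so far:
compound 1 `ClCc1ccc(Cn2cnc3c(Cl)ncnc32)cc1`: 30900 nM
compound 2 `Nc1nc(Cl)c2ncn(Cc3ccccc3CCl)c2n1`: 20900 nM
compound 3 `ClCc1cccc(Cn2cnc3nc(Cl)nc(Cl)c32)c1`: 400 nM

In a functional assay on SK-MEL-28 cells (Homo sapiens) for cytotoxicity, read by sulforhodamine B assay, with a stated time of 48 h (on this read-out higher numbers stand for weaker inhibition of growth and lower numbers for stronger inhibition of growth), compound 1 gives 30900 nM, the highest of the three numbers. Compound 2 sits within the scatter of it, so no order between the two can be stated. Compound 3 lies far lower at 400 nM, beyond the scatter.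

Compound 4 `ClCc1ccc(Cn2cnc3c(Cl)nc(Cl)nc32)cc1` is not yet measured. Relative to compound 1 it differs by chloro in place of hydrogen on an aromatic carbon. Among the measured compounds shown here, no measured pair shows this exact change. Because compound 3, which already carries this chloro on its core, gives 400 nM, a large downward step a 21-fold lower number from compound 1 to compound 4 (1.31 log units; beyond the scatter) is expected, though the benzyl part of compound 3 is not the same as in compound 4, so the full gain is uncertain. Compound 4 is estimated at 1500 nM, with a range from 300 nM to 8000 nM.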

Compound 4, concentration for total growth inhibition: 6920 nM
Compound 4: the middle estimate sits 4.6-fold (0.66 log units) below what was measured; low and high end bracket the measured number.
By their numbers in this assay, from the lowest: compound 3; then compound 4; then compounds 2 and 1 (each within the scatter of the next).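

Chloro in place of hydrogen on this aromatic carbon, between two ring nitrogen atoms, gives the first single-change step of the series: a 4.5-fold lower number from compound 1 to compound 4 (0.65 log units; beyond the scatter) in this assay. With the benzyl part held constant, the second chloro on the core therefore lowers the number by itself. No measurement shown accounts for this step.

As far as these compounds go, whether bromo or a methoxy group at this position would lower the number further remains open. So does whether the chloro step keeps its size with the chloromethyl group placed elsewhere on the benzyl ring.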